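Estimating Vero-cell Cytotoxicity for a 4-Bromophenyl Analogue

The source may report more compounds than this note shows. Statements on the series, on what has been measured and on what is new or still open speak of the compounds shown alone.

Measured compounds:
compound 1, `N/C(=N/NC(CC(=O)c1ccc(-n2ccnc2)cc1)c1ccc(Cl)cc1Cl)c1ccccn1`: 27800 nM
compound 2, `N/C(=N/NC(CC(=O)c1ccc(-n2ccnc2)cc1)c1cccc(Br)c1)c1ccccn1`: 51300 nM

In an ADME assay on Vero cells (Chlorocebus sabaeus) for cytotoxicity, read by MTT assay, with a stated time of 72 h (on this read-out higher numbers stand for lower toxicity in this test and lower numbers for higher toxicity in this test), compound 1 gives 27800 nM and compound 2 gives 51300 nM. Going by the values given here, compound 1 is the nearer of the two to the low end of the range, yet its only neighbour, compound 2, sits within the scatter of it: a 1.8-fold higher number from compound 1 to compound 2 (0.27 log units; within the scatter). Among the compounds with values here, that step, swapping the aryl group on the saturated chain carbon bound to an amine nitrogen and a saturated chain carbon, is the single piece of evidence available.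

The unmeasured compound 3, `N/C(=N/NC(CC(=O)c1ccc(-n2ccnc2)cc1)c1ccc(Br)cc1)c1ccccn1`, differs from compound 1 as follows: 4-bromophenyl in place of 2,4-dichlorophenyl on a saturated chain carbon bound to an amine nitrogen and a saturated chain carbon. This is the same kind of change as from compound 1 to compound 2, a single halogenated phenyl ring exchanged for another at the same place, and that step stayed within the scatter in this assay. Nothing here distinguishes 4-bromophenyl from 3-bromophenyl, so no step beyond the scatter is expected for compound 3, with the number estimated to fall near or a little above compound 1 because of a 1.8-fold higher number from compound 1 to compound 2 (0.27 log units; within the scatter).

The expected step is a 1.4-fold higher number from compound 1 to compound 3 (0.14 log units; within the scatter). For compound 3 the estimate in this assay is 38000 nM, within 17000 nM to 85000 nM.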

Compound 3, half-maximal cytotoxic concentration: 298000 nM
Estimate against measurement, compound 3: 7.8-fold (0.89 log units) below; measured number outside the range, above it.
By their numbers in this assay, from the lowest: compounds 1 and 2 (each within the scatter of the next); then compound 3.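

In this assay, the place on a saturated chain carbon bound to an amine nitrogen and a saturated chain carbon no longer looks tolerant of exchanging one halogenated phenyl ring for another: 4-bromophenyl in place of 2,4-dichlorophenyl gives an 11-fold higher number from compound 1 to compound 3 (1.03 log units; beyond the scatter), whereas the earlier pair had stayed within the scatter. The two bromophenyl groups also part company, since 4-bromophenyl in place of 3-bromophenyl gives a 5.8-fold higher number from compound 2 to compound 3 (0.76 log units; beyond the scatter), so sharing the same halogen does not make two rings interchangeable here, and compound 3 is the least toxic of the three in this test. Nothing available accounts for why the 4-bromophenyl group stands apart from the other two.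

The compounds shown leave open whether the higher number belongs to bromine itself or would also appear with a 4-chlorophenyl or 4-fluorophenyl group at this place, and where an unsubstituted phenyl group would fall. They also leave open whether the gap would survive a change elsewhere in the shared core, such as a methyl group on the amine nitrogen.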